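A few compounds are considered here, and "the series" means these few. Any claim that something is new, unique, unknown or untested is made for them only; others in the source may bear on it.

Measured in an ADME assay on RAW264.7 cells (Mus musculus) for cytotoxicity, read by MTT assay, with a stated time of 24 h, in the absence of a further agent; a higher number here means a weaker inhibitor, a lower number a stronger inhibitor:
- compound 1 `O=C1OC(Cc2nc(-c3ccccc3)no2)c2ccccc21`: > 40000 nM, a limit
- compound 2 `O=C1OC(Cc2nc(-c3ccc(Oc4ccccc4)cc3)no2)c2ccccc21`: > 40000 nM, a limit
- compound 3 `COc1ccc(C(O)C2OC(=O)c3c(OC)cc(OC)cc32)cc1`: > 40000 nM, a limit

Compound 3 gives no number, only the limit > 40000 nM. The series as a whole reads (the limit of > 40000 nM in this assay, at which 3 of the 3 values shown sit). Compound 4 `COCCCOc1ccc(C(O)C2OC(=O)c3c(OC)cc(OC)cc32)cc1` carries 2-methoxyethyl in place of hydrogen on a saturated chain carbon bound to an oxygen on an aromatic ring, which also reads as methoxy to 3-methoxypropoxy. Among the measured compounds shown here, the one measured step, a step that the two limits leave unreadable from compound 1 to compound 2, belongs to another core and has no readable size, so it gives no measure for this change. No direction can be read from it either. The expected step in this assay is a number no higher from compound 3 to compound 4 (the limit leaves the size open), with no shift expected beyond the scatter. The estimate for compound 4 is 40000 nM, with an expected range of 18000 nM to 80000 nM.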

Compound 4, half-maximal inhibitory concentration: > 40000 nM
Compound 4 gave a limit, no number; the forecaster's own chance of this, stated with the estimate: 80%; the middle value lies on the limit itself.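

In this assay, no step can be read between compound 3 and compound 4, as both stand at a limit: the limit of > 40000 nM in this assay, at which 4 of the 4 values shown sit.

Whether 3-methoxypropoxy in place of methoxy shifts the read-out at all stays open, as does any ranking of the compounds shown.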